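Chalcone direction reversed on the pyrazolopyrimidine-type core series

The source may hold more compounds than are shown below. What is called first, only, known or untested is meant among the compounds shown, and "the series" means these compounds.

Compound 1 `COc1ccc(C(=O)/C=C/c2cc(-c3cc(OC)c(OC)c(OC)c3)n3nc(-c4ccccc4)cc3n2)cc1` stands highest of the three numbers obtained in an ADME assay on HEK293 cells (Homo sapiens) for antiproliferative activity, read by MTT assay, with a stated time of 24 h (a higher number here means a weaker inhibitor, a lower number a stronger inhibitor), where compound 1 gives 79800 nM. Compound 2 `COc1ccc(-c2cc(/C=C/C(=O)c3cc(OC)c(OC)c(OC)c3)nc3cc(-c4ccccc4)nn23)cc1OC` gives 35000 nM and compound 3 `COc1ccc(C(=O)/C=C/c2cc(-c3ccc(OC)c(OC)c3)n3nc(-c4ccccc4)cc3n2)cc1OC` gives 32500 nM; both lie below compound 1 by more than the scatter, and the two of them are within the scatter of each other. Among the compounds with values here, the one single-point step measured, a 1.1-fold lower number from compound 2 to compound 3 (0.03 log units; within the scatter), touches only a methoxy on the chalcone aryl and says nothing about the orientation of the enone.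

Compound 4 `COc1ccc(/C=C/C(=O)c2cc(-c3cc(OC)c(OC)c(OC)c3)n3nc(-c4ccccc4)cc3n2)cc1` differs from compound 1 by (2-(4-methoxyphenyl)ethenyl)carbonyl in place of 2-((4-methoxyphenyl)carbonyl)ethenyl on an aromatic carbon: the same atoms, joined the other way round, so that the carbonyl now sits on the core and the 4-methoxyphenyl on the ethenyl end. Within the data shown here, no measured pair in the set tests this reversal. Compounds 2 and 3 both keep the orientation of compound 1 and differ from it in other substituents. Among the measured compounds shown here, with no bearing step, the expectation for compound 4 is no change beyond the scatter in this assay, expressed as a 1.2-fold lower number from compound 1 to compound 4 (0.09 log units; within the scatter). The estimate for compound 4 is therefore 65000 nM, with a range from 22000 nM to 180000 nM reflecting the absence of any comparable measured step.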

Compound 4, half-maximal inhibitory concentration: 46600 nM
Compound 4: the middle estimate sits 1.4-fold (0.14 log units) above what was measured; the range from low to high includes it.
By their numbers in this assay, from the lowest: compounds 3, 2, 4 and 1 (each within the scatter of the next, the first and the last beyond it).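

In this assay, within the data shown here, moving the carbonyl onto the core and the 4-methoxyphenyl onto the ethenyl end gives a 1.7-fold lower number from compound 1 to compound 4 (0.23 log units; within the scatter) and is the first direct reading of this reversal on the aromatic carbon of the six-membered ring with 2 nitrogen. For this one pair, with the 3,4,5-trimethoxyphenyl group kept in place, the direction of the enone therefore makes no difference that can be told from the scatter, so exchanging 2-((4-methoxyphenyl)carbonyl)ethenyl for (2-(4-methoxyphenyl)ethenyl)carbonyl offers no measurable gain or loss here. No supporting measurement bears on this outcome.

Still open is whether the same reversal would read the same way on the methoxy patterns of compound 2 and compound 3, since the compounds shown offer no reversed partner for either. Also open, on these data alone, is whether a change to the group itself would move the number beyond the scatter, for example an amine or a carboxylic acid on the aryl ring of the enone, or a longer chain in place of the ethenyl link.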